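Vero cytotoxicity notes: swapping halogens on the aryl ketone

The source may hold more compounds than are shown below. What is called first, only, known or untested is meant among the compounds shown, and "the series" means these compounds.

Cytotoxicity in an ADME assay on Vero cells (Chlorocebus sabaeus) for cytotoxicity, read by resazurin assay, with a stated time of 72 h; on this read-out higher numbers stand for weaker inhibition and lower numbers for stronger inhibition:
compound 1 `Cc1ccc(C(=O)CCN2CCN(c3ccc(Cl)cc3)CC2)cc1`: 184000 nM
compound 2 `O=C(CCN1CCN(c2ccc(Cl)cc2)CC1)c1ccc(F)c(F)c1`: 86200 nM
compound 3 `O=C(CCN1CCN(c2ccc(Cl)cc2)CC1)c1ccc(F)c(Cl)c1`: 114000 nM

Compound 3 stands second highest of the three numbers in this assay; both steps that end at it lie within the scatter: a 1.3-fold higher number from compound 2 to compound 3 (0.12 log units; within the scatter) and a 1.6-fold lower number from compound 1 to compound 3 (0.21 log units; within the scatter). Compound 4 `O=C(CCN1CCN(c2ccc(Cl)cc2)CC1)c1ccc(Cl)c(F)c1` differs from compound 3 by 4-chloro-3-fluorophenyl in place of 3-chloro-4-fluorophenyl on a carbonyl carbon. For the measured compounds named here, only the steps at the carbonyl-bound aryl bear on this change: a 2.1-fold lower number from compound 1 to compound 2 (0.33 log units; beyond the scatter) is modest, and the single halogen exchange a 1.3-fold higher number from compound 2 to compound 3 (0.12 log units; within the scatter) is within the scatter. Exchanging the places of the two halogens is therefore expected to give no step beyond the scatter, a 1.1-fold lower number from compound 3 to compound 4 (0.04 log units; within the scatter). Compound 4 is estimated at 105000 nM in this assay, with a range from 55000 nM to 200000 nM.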

Compound 4, half-maximal inhibitory concentration: 175000 nM
Beside the measured number, compound 4's estimate is 1.7-fold (0.22 log units) below it; the range from low to high includes it.
By their numbers in this assay, from the lowest: compounds 2, 3, 4 and 1 (each within the scatter of the next, the first and the last beyond it).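

In this assay, exchanging the places of the two halogens on the carbonyl-bound aryl gives (a 1.5-fold higher number from compound 3 to compound 4 (0.19 log units; within the scatter)), so this swap alone does not separate the two isomers. Chloro in place of fluoro reaches a modest step beyond the scatter when it gives the 4-chloro-3-fluorophenyl group (a 2.0-fold higher number from compound 2 to compound 4 (0.31 log units; beyond the scatter)), whereas the exchange giving the 3-chloro-4-fluorophenyl group stayed within it. The 4-chloro-3-fluorophenyl group also cannot be told apart from 4-methylphenyl (a 1.1-fold lower number from compound 1 to compound 4 (0.02 log units; within the scatter)).

Open, on these data alone, is how an amine or a carboxylic acid on this aryl, or a longer chain on the carbonyl carbon, would read here. No measurement at hand accounts for these steps.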